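From Pentylphenyl to Butyl on the Shared Core

The source may report more compounds than this note shows. Statements on the series, on what has been measured and on what is new or still open speak of the compounds shown alone.

Three measured compounds share one core.
Compound 1, `C[Si](C)(C)c1cn(C[C@H](O)[C@H]2OC(=O)C(OCc3ccccc3)=C2OCc2ccccc2)nn1`, in a functional assay on HCT-116 cells (Homo sapiens) for antiproliferative activity, read by MTT assay, with a stated time of 72 h (a higher number here means a weaker inhibitor, a lower number a stronger inhibitor), gives 31800 nM.
Compound 2, `COc1ccc(-c2cn(C[C@H](O)[C@H]3OC(=O)C(OCc4ccccc4)=C3OCc3ccccc3)nn2)cc1`, in this assay gives only a limit of the assay, > 100000 nM.
Compound 3, `CCCCCc1ccc(-c2cn(C[C@H](O)[C@H]3OC(=O)C(OCc4ccccc4)=C3OCc3ccccc3)nn2)cc1`, in this assay gives 13800 nM.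

Compound 3 stands lowest of the two proper numbers. Compound 1 is its nearest neighbour, and the step of a 2.3-fold lower number from compound 1 to compound 3 (0.36 log units; beyond the scatter) lies beyond the scatter. In the other direction, the step of an at least 3.1-fold higher number from compound 1 to compound 2 (0.49 log units; beyond the scatter) shows that a methoxyphenyl group sits past the limit, and an at least 7.2-fold lower number from compound 2 to compound 3 (0.86 log units; beyond the scatter) shows how far pentyl and methoxy on the same ring lie apart.

Compound 4, `CCCCc1cn(C[C@H](O)[C@H]2OC(=O)C(OCc3ccccc3)=C2OCc2ccccc2)nn1`, has not yet been measured. Its change from compound 3 is butyl in place of 4-pentylphenyl on an aromatic carbon. Butyl, like the trimethylsilyl group of compound 1, carries no ring, whereas the group that leaves carries the ring shared by compounds 2 and 3. The step that bears most directly on this change is a 2.3-fold lower number from compound 1 to compound 3 (0.36 log units; beyond the scatter), read backwards: removing the ring-bearing group in favour of a small chain without a ring went with a modest rise from compound 3 to compound 1. A rise of similar size is therefore expected here, beyond the scatter but not large. Compound 4 is expected to give about 30000 nM, between 10000 nM and 100000 nM, which means an expected step of a 2.2-fold higher number from compound 3 to compound 4 (0.34 log units; beyond the scatter).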

Compound 4, half-maximal inhibitory concentration: 10400 nM
Compound 4: the middle estimate sits 2.9-fold (0.46 log units) above what was measured, and the stated range covers the measured number.
By their numbers in this assay, from the lowest: compounds 4 and 3 (each within the scatter of the next); then compound 1. At a limit, above all of these: compound 2.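

Butyl in place of 4-pentylphenyl on this aromatic carbon gives, in this assay, a 1.3-fold lower number from compound 3 to compound 4 (0.12 log units; within the scatter) and so leaves the two compounds indistinguishable: a ring in this group is not needed to reach a number of this size. The earlier compounds shown here could not show this, and they also left the two groups without a ring untested against each other, yet butyl in place of trimethylsilyl gives a 3.1-fold lower number from compound 1 to compound 4 (0.49 log units; beyond the scatter) and so the absence of a ring does not by itself set the number at this position. The 4-methoxyphenyl group stays apart from the others, with butyl in its place giving an at least 9.6-fold lower number from compound 2 to compound 4 (0.98 log units; beyond the scatter) and that step starts from a limit of the assay, not a number: the limit of > 100000 nM in this assay, at which 1 of the 4 values shown sits.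

Still open, going by these compounds, is whether a shorter chain such as ethyl or a longer chain such as octyl on this carbon would move the number beyond the scatter. Also open, on these data alone, is whether a butyl chain ending in an amine or a carboxylic acid would keep the number where it stands.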